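Benzoyl to Cyano Swap on Two Related Cores

The source may report more compounds than this note shows. Statements on the series, on what has been measured and on what is new or still open speak of the compounds shown alone.

Compound 1 `C=C[C@@](C)(/C=C/c1ccc(O)cc1)CC/C=C/C(=O)c1ccccc1` — > 36600 nM
Compound 2 `C=C[C@@](C)(/C=C/c1ccc(O)cc1)CC/C=C/C#N` — > 36600 nM
Compound 3 `C=C[C@@](C)(/C=C/c1ccc(O)c(/C=C/C(=O)c2ccccc2)c1)CCC=C(C)C` — 8000 nM

Three compounds were tested in a functional assay on SEM cells (Homo sapiens) for cytotoxicity, with a stated time of 72 h; on this read-out higher numbers stand for an effect only at larger amounts of compound and lower numbers for an effect already at smaller amounts. Compound 1 reaches only a limit of the assay, > 36600 nM. Compound 2 likewise gives only a limit, > 36600 nM. Among the measured compounds shown here, compound 3 gives 8000 nM, the only number among the three. The change from compound 1 to compound 2 is cyano in place of benzoyl on a double-bonded chain carbon bound to a double-bonded chain carbon and its step is a step that the two limits leave unreadable from compound 1 to compound 2, because both values sit at the limit of > 36600 nM in this assay, at which 2 of the 3 values shown sit. Compound 4 `C=C[C@@](C)(/C=C/c1ccc(O)c(/C=C/C#N)c1)CCC=C(C)C` is not yet measured; it carries the same change on the core of compound 3: cyano in place of benzoyl on a double-bonded chain carbon bound to a double-bonded chain carbon. The difference between the two cores is not broken down here. For the measured compounds named here, compound 2, the one measured compound bearing cyano, gives only a limit, > 36600 nM. On that basis compound 4 is expected near 25000 nM, likely within 8000 nM to 60000 nM, with a real chance of another limit. For compound 4 this means an expected step of a 3.1-fold higher number from compound 3 to compound 4 (0.49 log units; beyond the scatter).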

Compound 4, half-maximal effective concentration: > 36600 nM
Compound 4: a limit, no number; the forecaster's own chance of this, stated with the estimate: 55%; middle value at least 1.4-fold (0.16 log units) away from the limit.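

Carried to the second core, cyano in place of benzoyl gives an at least 4.5-fold higher number from compound 3 to compound 4 (0.66 log units; beyond the scatter) in this assay. Compound 4 reaches only a limit, > 36600 nM, so the step has a lower bound but no exact size. The same change on the first core cannot be read, so the data do not show whether the change has the same size on both cores: the limit of > 36600 nM in this assay, at which 3 of the 4 values shown sit.

The compounds shown leave open whether the benzoyl ring is needed on the core of compound 3, or whether acetyl, which keeps the carbonyl without that ring, would serve as well. They also leave open how an amine or a carboxylic acid would fare at the same place.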